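From trifluoromethoxy to methylsulfanyl on a shared core

This account rests on a few compounds, and the source may have more. Where it says the series, first, only, none or still open, it means among the compounds named here.

Compound 1 `O=C(CCc1cccc2c1B(O)OC2)Nc1ccccc1`: 200 nM
Compound 2 `O=C(CCc1cccc2c1B(O)OC2)Nc1cccc(-c2cccc(F)c2)c1`: 480 nM
Compound 3 `O=C(CCc1cccc2c1B(O)OC2)Nc1cccc(-c2ccc(OC(F)(F)F)cc2)c1`: 560 nM

All three compounds were tested in a functional assay on SK-OV-3 cells (Homo sapiens) for antiproliferative activity, read by MTT assay, with a stated time of 72 h; on this read-out lower numbers stand for stronger inhibition and higher numbers for weaker inhibition. Compound 3 has the highest number of the three. It lies within the scatter of compound 2 and beyond the scatter of compound 1, so it is clearly a weaker inhibitor only than compound 1.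

The next compound is compound 4 `CSc1ccc(-c2cccc(NC(=O)CCc3cccc4c3B(O)OC4)c2)cc1`. It has methylsulfanyl in place of trifluoromethoxy on an aromatic carbon, and the rest of the structure stays the same.

Within the data shown here, no measured step makes this exact swap, so the evidence is indirect. Among the measured compounds shown here, the only measured step is a 2.4-fold higher number from compound 1 to compound 2 (0.38 log units; beyond the scatter), a modest change that installs a 3-fluorophenyl group in place of hydrogen. Compound 2 gives 480 nM and compound 3 gives 560 nM, two values within the scatter of each other even though their aryl groups carry different substituents. Three compounds are too few to establish a pattern, but they give no reason to expect a large shift. No step beyond the scatter is therefore expected in this assay, and the expected change is a 1.1-fold lower number from compound 3 to compound 4 (0.05 log units; within the scatter). The estimated value for compound 4 is 500 nM, with an expected range of 230 nM to 1050 nM.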

Compound 4, half-maximal inhibitory concentration: 140 nM
For compound 4 the middle estimate is 3.6-fold (0.55 log units) above the measured one; the measured number lies below the stated range.
By their numbers in this assay, from the lowest: compounds 4 and 1 (each within the scatter of the next); then compounds 2 and 3 (each within the scatter of the next).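

Methylsulfanyl in place of trifluoromethoxy, para to a large group, gives a 4.0-fold lower number from compound 3 to compound 4 (0.60 log units; beyond the scatter) in this assay, so the small substituent at this position can shift the number beyond the scatter, something the earlier compounds did not reveal. The same holds when the whole aryl group is changed: 4-(methylsulfanyl)phenyl in place of 3-fluorophenyl gives a 3.4-fold lower number from compound 2 to compound 4 (0.54 log units; beyond the scatter) and so recovers what was lost in a 2.4-fold higher number from compound 1 to compound 2 (0.38 log units; beyond the scatter) when the 3-fluorophenyl group was added. Set against the hydrogen of compound 1, 4-(methylsulfanyl)phenyl gives a 1.4-fold lower number from compound 1 to compound 4 (0.15 log units; within the scatter), which shows that a large aryl group can be carried here with no change beyond the scatter, provided it bears the right substituent.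

No measurement of any property of these groups accompanies the numbers, so the reason for the difference stays open. The compounds shown also do not tell how a methoxy group, an amine or a longer chain such as ethylsulfanyl would fare at this same place.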